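The source may hold more compounds than are shown below. What is called first, only, known or untested is meant among the compounds shown, and "the series" means these compounds.

Measured so far in a functional assay on U-373MG ATCC cells (Homo sapiens), read by thymidine incorporation (a lower number here means a stronger inhibitor, a higher number a weaker inhibitor), for the series:
- compound 1 `CCCCCCCCCCCCCCCCO[C@H]1O[C@H](COCC(CO)(CO)CO)[C@@H](O)[C@H](O)[C@H]1NC(=O)CCCC` gives 27.3 uM on the polyol ether
- compound 2 `CCCCC(=O)N[C@H]1[C@@H](OCCc2ccccc2)O[C@H](COCC(O)CO)[C@@H](O)[C@@H]1O` gives > 50 uM as a limit
- compound 3 `CCCCCCCCCCCCCCCCO[C@H]1O[C@H](COC[C@H](O)CO)[C@@H](O)[C@H](O)[C@H]1NC(=O)CCCC` gives 4.9 uM on the diol ether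

Compound 3 at 4.9 uM holds the lower of the two exact numbers. The entry for compound 2 is only a limit.

Compound 4 `CCCCCCCCCCCCCCCCO[C@H]1O[C@H](COC[C@@H](O)CO)[C@@H](O)[C@H](O)[C@H]1NC(=O)CCCC` relates to compound 3 as follows: the two compounds have the same atoms and bonds and differ only in configuration as drawn: 1 of 6 stereo elements differ; a stereocentre at a saturated chain carbon is drawn R in compound 3 and S in compound 4 and no group leaves or enters. Among the compounds with values here, the one measured step on this chain is a 5.6-fold lower number from compound 1 to compound 3 (0.75 log units; beyond the scatter) and it swaps a group, so no measured pair tests this configuration. A smaller step is expected, probably none beyond the scatter, with no direction favoured. Compound 4 is expected at 5.5 uM with an estimated range of 2 uM to 14 uM in this assay readings. The estimate amounts to an expected 1.1-fold higher number from compound 3 to compound 4 (0.05 log units; within the scatter).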

Compound 4, concentration for 50% inhibition: 5.6 uM
For compound 4 the middle estimate is 1.0-fold (0.01 log units) below the measured one, within the range that was stated.
By their numbers in this assay, from the lowest: compounds 3 and 4 (each within the scatter of the next); then compound 1. At a limit, above all of these: compound 2.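

In this assay, within the data shown here, inverting the stereocentre at the saturated chain carbon of the diol ether gives a 1.1-fold higher number from compound 3 to compound 4 (0.06 log units; within the scatter), so the configuration drawn at this carbon does not separate the two diols, a point no earlier pair could test. The swap of 2-hydroxy-1,1-bis(hydroxymethyl)ethyl for 1,2-dihydroxyethyl also holds with the other configuration, giving a 4.9-fold lower number from compound 1 to compound 4 (0.69 log units; beyond the scatter), so that step does not rest on one stereoisomer.

Still open, on these data alone, is how an amine or a carboxylic acid in place of 1,2-dihydroxyethyl would read in this assay.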